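From methoxymethoxy to fluoro: compound 2 to compound 3

The source may hold more compounds than are shown below. What is called first, only, known or untested is meant among the compounds shown, and "the series" means these compounds.

In a functional assay on MCF7 cells (Homo sapiens) for inhibition, read by MTT assay, with a stated time of 3 days (on this read-out higher numbers stand for weaker inhibition and lower numbers for stronger inhibition), compound 1 `COCOc1ccccc1/C=C/CCCOc1cc(/C=C\c2cc(OC)c(OC)c(OC)c2)ccc1OC` gives 4400 nM and compound 2 `COCOc1ccc(/C=C/CCCOc2cc(/C=C\c3cc(OC)c(OC)c(OC)c3)ccc2OC)cc1` gives 42000 nM, so compound 2 holds the higher of the two numbers and is the weaker inhibitor of the pair. Compound 3 `COc1ccc(/C=C\c2cc(OC)c(OC)c(OC)c2)cc1OCCC/C=C/c1ccc(F)cc1` differs from compound 2 by fluoro in place of methoxymethoxy on an aromatic carbon, para to a large group: fluoro in place of methoxymethoxy on an aromatic carbon.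

For the measured compounds named here, only one measured step bears on this change, and only indirectly. The step of a 9.5-fold higher number from compound 1 to compound 2 (0.98 log units; beyond the scatter) is modest but beyond the scatter, and it exchanges 2-(methoxymethoxy)phenyl for 4-(methoxymethoxy)phenyl rather than removing the group. Going by the values given here, no measured compound shows the effect of fluoro. That step still sets a working size for changes on this ring in this assay, and a step of no greater size is expected here. With compound 2 at the top of the two numbers, the direction is expected to be downward, with low confidence. The estimated change is a 2.8-fold lower number from compound 2 to compound 3 (0.45 log units; beyond the scatter). For compound 3 the estimate is 15000 nM, with an expected range of 4000 nM to 50000 nM.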

Compound 3, half-maximal inhibitory concentration: 16000 nM
Compound 3: the middle estimate sits 1.1-fold (0.03 log units) below what was measured, within the range that was stated.
By their numbers in this assay, from the lowest: compound 1; then compound 3; then compound 2.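

In this assay, fluoro in place of methoxymethoxy on the same aromatic carbon, para to a large group, gives a 2.6-fold lower number from compound 2 to compound 3 (0.42 log units; beyond the scatter), so the methoxymethoxy group at this place is not required for the activity seen: a single fluorine stands in for 4 heavy atoms and 2 hydrogen-bond acceptors, and the number still goes down. The gain is only partial, since a 3.6-fold higher number from compound 1 to compound 3 (0.56 log units; beyond the scatter) leaves compound 1 with the lowest number of the three, its steps to compound 2 and compound 3 both being beyond the scatter. Nothing available explains either step.

The compounds shown leave open whether the lower number of compound 3 comes from the loss of methoxymethoxy or from the presence of fluoro, a question that an unsubstituted phenyl ring would help to separate. Also open, from the compounds shown here alone, is how an amine or a carboxylic acid on this aromatic carbon would read, and whether the 2-(methoxymethoxy)phenyl of compound 1 keeps its lead over other groups carried at that place.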